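Adding a Methyl to the Amine Nitrogen

The source may hold more compounds than are shown below. What is called first, only, known or untested is meant among the compounds shown, and "the series" means these compounds.

Of the compounds shown here, two of one shared core have been measured in an in vitro functional assay on cells for antagonist activity at metabotropic glutamate receptor 1 (Rattus norvegicus), read by inositol phosphate accumulation; a higher number here means a weaker inhibitor, a lower number a stronger inhibitor. Compound 1 `CC1(C)CC(=O)c2cc(C#N)c(SCc3ccccc3)nc2C1` gives 4800 nM, and compound 2 `CC1(C)CC(=O)c2cc(C#N)c(NCc3ccccc3)nc2C1` gives 2500 nM. These two values lie within the scatter of each other, so neither compound can be set apart from the other on this evidence. Compound 3 `CN(Cc1ccccc1)c1nc2c(cc1C#N)C(=O)CC(C)(C)C2` is not yet measured. It differs from compound 2 by methyl in place of hydrogen on a nitrogen on an aromatic ring. Going by the values given here, no step between measured compounds shows what such a change does here. The change is expected to move the number only a little: a 1.4-fold higher number from compound 2 to compound 3 (0.15 log units; within the scatter), with no direction beyond the scatter. Compound 3 is therefore expected to give about 3500 nM, with a range from 1000 nM to 12000 nM.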

Compound 3, half-maximal inhibitory concentration: 5300 nM
Beside the measured number, compound 3's estimate is 1.5-fold (0.18 log units) below it, within the range that was stated.
By their numbers in this assay, from the lowest: compounds 2, 1 and 3 (each within the scatter of the next, the first and the last beyond it).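

In this assay, methyl in place of hydrogen on this nitrogen gives a 2.1-fold higher number from compound 2 to compound 3 (0.33 log units; beyond the scatter) as a modest step, just beyond the scatter. Going by these compounds alone, this is the first direct reading of a change at this nitrogen: one added carbon is enough to make a somewhat weaker inhibitor. No measurement shown explains why the number rises. As far as these compounds go, whether an ethyl group or a longer chain on this nitrogen would weaken inhibition further remains open. So does whether an acetyl group there would give a different result.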